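The compounds below may be only part of what the source reports. "The series", "measured", "known", "first", "only" and "open" are said of these compounds alone.

Compound 2 `Cc1nc(C)c(S(=O)(=O)NC(=O)NC/C=C2\CCCc3cnn(Cc4ccc(Cl)cc4Cl)c32)s1` gives 2 nM in an assay on isolated protein for displacement of a labelled ligand from prostaglandin E2 receptor EP3 subtype (Homo sapiens), read by scintillation counting, with a stated time of 2 h; on this read-out higher numbers stand for weaker inhibition and lower numbers for stronger inhibition. Compound 1 `COc1ccc(Cl)cc1S(=O)(=O)NC(=O)NC/C=C1\CCCc2cnn(Cc3ccc(Cl)cc3Cl)c21` gives 3 nM in this assay, and the two numbers sit within the scatter of each other: a 1.5-fold lower number from compound 1 to compound 2 (0.18 log units; within the scatter). Compound 3 `Cn1cc(S(=O)(=O)NC(=O)NC/C=C2\CCCc3cnn(Cc4ccc(Cl)cc4Cl)c32)cn1` carries the change (1-methyl-1H-pyrazol-4-yl in place of 2,4-dimethyl-1,3-thiazol-5-yl on a sulfonyl sulfur). Among the compounds with values here, the only measured step that bears on a swap of the ring on the sulfonyl sulfur is the one from compound 1 to compound 2, which stayed within the scatter, so no step beyond the scatter is expected here either. Compound 3 is estimated at 4 nM in this assay, range 1.5 nM to 12 nM. The expected step is a 2.0-fold higher number from compound 2 to compound 3 (0.30 log units; within the scatter).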

Compound 3, inhibition constant: 9 nM
For compound 3 the middle estimate is 2.3-fold (0.35 log units) below the measured one, and the stated range covers the measured number.
By their numbers in this assay, from the lowest: compounds 2 and 1 (each within the scatter of the next); then compound 3.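

Within the data shown here, on a sulfonyl sulfur, the ring is not freely exchangeable: 1-methyl-1H-pyrazol-4-yl in place of 2,4-dimethyl-1,3-thiazol-5-yl gives a 4.5-fold higher number from compound 2 to compound 3 (0.65 log units; beyond the scatter) and in place of 5-chloro-2-methoxyphenyl gives a 3.0-fold higher number from compound 1 to compound 3 (0.48 log units; beyond the scatter) as modest steps, whereas the only earlier swap stayed within the scatter. Nothing at hand explains these steps.

The change alters the ring atoms and the methyl substitution together, and the compounds shown do not separate the two. Open, on these data alone, is where a pyrazole ring with a second methyl group, or a pyridine ring, would fall on a sulfonyl sulfur.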